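Removing a Silyl Group from a Long-Chain Thioether Analogue

A few compounds are considered here, and "the series" means these few. Any claim that something is new, unique, unknown or untested is made for them only; others in the source may bear on it.

Compound 1 `Cn1nc(Cc2nnc(SCC(=O)Nc3ccc(Cl)cc3Cl)n2CCC=O)c2ccccc2c1=O` — 6400 nM
Compound 2 `Cn1c(Cc2nn(CCC=O)c(=O)c3ccccc23)nnc1SCC(=O)Nc1ccc(Cl)cc1Cl` — 30000 nM
Compound 3 `Cn1c(Cc2nn(CCCO[Si](C)(C)C(C)(C)C)c(=O)c3ccccc23)nnc1SCCCCCCCC(=O)Nc1ccc(Cl)cc1Cl` — > 30000 nM

Of the compounds shown here, three have been tested in an assay on 32D cells for inhibition of interleukin-15 (Mus musculus), read by resazurin assay, with stated times of 30 min and 2.5 days, in the presence of a further agent that is not named here; on this read-out higher numbers stand for weaker inhibition and lower numbers for stronger inhibition. Compound 1 gives 6400 nM in this assay, and compound 2 gives 30000 nM. For compound 3 this assay reports only a limit, > 30000 nM, so no number is known for it; this is the limit of > 30000 nM in this assay, at which 1 of the 3 values shown sits. Within the data shown here, compound 3 therefore stands apart from the other two in that its value is not a measured point at all, and no step between measured compounds can be drawn from it.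

Compound 4 `Cn1c(Cc2nn(CCCO)c(=O)c3ccccc23)nnc1SCCCCCCCC(=O)Nc1ccc(Cl)cc1Cl` has not yet been measured. It differs from compound 3 by a hydrogen atom in place of a group of 7 heavy atoms (6 carbon, 1 silicon; no ring), on an oxygen on a saturated carbon, so that a free hydroxyl now ends the chain where a silicon-bearing group stood before. The step from compound 3 to compound 4 starts from a limit, so its size can only be guessed; the step of compound 3 to compound 4 is expected to be a number no higher from compound 3 to compound 4 (the limit leaves the size open), which is small and may well stay within the usual scatter. Compound 4 is accordingly expected to give about 30000 nM in this assay, within a range of 8000 nM to 100000 nM, with a real chance that this assay again returns only a limit.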

Compound 4, half-maximal inhibitory concentration: > 30000 nM
Compound 4 was reported as a limit; the forecaster's own chance of this, stated with the estimate: 55%; the middle value sits exactly at the limit.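

Among these compounds, compound 4, like compound 3, is reported only as a limit, so no step from compound 3 to compound 4 can be read: the limit of > 30000 nM in this assay, at which 2 of the 4 values shown sit. The compounds shown leave open what number either compound would give, and so whether a hydrogen atom in place of the silicon-bearing group changes the inhibition at all.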